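The source may hold more compounds than are shown below. What is called first, only, known or untested is meant among the compounds shown, and "the series" means these compounds.

Measured compounds:
- compound 1 `Nc1c(C(=O)N[C@H]2CC[C@@H](c3ccccc3)CC2)[nH]c(=O)[nH]c1=O`, result in an assay on isolated protein for inhibition of endothelial lipase (Homo sapiens), read by LC-MS, with a stated time of 2 h, in the presence of a further agent that is not named here; a higher number here means a weaker inhibitor, a lower number a stronger inhibitor: "not determined" (no result reported)
- compound 2 `Nc1c(C(=O)N[C@H]2CC[C@@H](c3ccc(OCc4ccccc4)cc3)CC2)[nH]c(=O)[nH]c1=O`, result in this assay: 35000 nM

Compound 1 has no single number to stand on: in this assay compound 1 returned no result. For the measured compounds named here, the only number at hand comes from compound 2, which shares the core of compound 1 and carries a benzyloxy group on its phenyl ring; in this assay compound 2 gives 35000 nM, a weak result.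

Compound 3 `O=C(N[C@H]1CC[C@@H](c2ccccc2)CC1)c1[nH]c(=O)[nH]c(=O)c1NC1CCCC1` is compound 1 with one change: cyclopentyl in place of hydrogen on a nitrogen on an aromatic ring. Going by the values given here, with no step between measured compounds to lean on, the expected size of this step in this assay is small, no further than the usual scatter, in no settled direction. Taking the weak result of compound 2 as the only anchor, compound 3 is expected to be a weak inhibitor, with an estimated value of 25000 nM and a likely range from 5000 nM to 120000 nM.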

Compound 3, half-maximal inhibitory concentration: 436000 nM
Estimate against measurement, compound 3: 17-fold (1.24 log units) below; measured number above the stated range.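

In this assay, for the compounds shown here, compound 1 carries no number, and no step to compound 3 can be read from it. The compounds shown leave open what the change from amino to cyclopentylamino does to inhibition. No outside evidence bears on this result.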